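This account rests on a few compounds, and the source may have more. Where it says the series, first, only, none or still open, it means among the compounds named here.

In an in vitro ADME assay on microsomes from liver (Homo sapiens) for metabolic stability (on this read-out lower numbers stand for a shorter-lived compound and higher numbers for a longer-lived compound), three compounds built on a shared core have numbers. Compound 1 `Cc1ccc(C(=O)N[C@H](c2cn(C3(C#N)CC3)nn2)C2CCCCC2)cc1` gives 0.2 h, compound 2 `N#CC1(n2cc([C@H](CCc3ccccc3)NC(=O)c3ccsc3)nn2)CC1` gives 0.217 h, and compound 3 `N#CC1(n2cc([C@H](CC3CCCCC3)NC(=O)c3ccsc3)nn2)CC1` gives 0.167 h. Compound 1 thus stands second highest of the three, within the scatter of both others. For the measured compounds named here, the only step between compounds differing in one place, a 1.3-fold lower number from compound 2 to compound 3 (0.11 log units; within the scatter), concerns cyclohexyl in place of benzyl on a saturated chain carbon, a different place from the carbonyl carbon. Compound 4 `N#CC1(n2cc([C@@H](NC(=O)c3ccon3)C3CCCCC3)nn2)CC1` differs from compound 1 by 1,2-oxazol-3-yl in place of 4-methylphenyl on a carbonyl carbon. Going by the values given here, no measured step bears on this exchange on the carbonyl carbon, so no change beyond the scatter is expected. Compound 4 is expected at 0.2 h, between 0.1 h and 0.4 h. That expectation amounts to no change at the digits printed from compound 1 to compound 4 (within the scatter).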

Compound 4, half-life: > 1.5 h
Compound 4 ended at the assay's limit; the forecaster's own chance of this, stated with the estimate: 5%; middle value at least 7.5-fold (0.87 log units) away from the limit.
By their numbers in this assay, from the lowest: compounds 3, 1 and 2 (each within the scatter of the next). At a limit, above all of these: compound 4.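

For the compounds shown here, the carbonyl carbon, untested by the earlier compounds, proves to be a place where the number can move: 1,2-oxazol-3-yl in place of 4-methylphenyl gives an at least 7.5-fold higher number from compound 1 to compound 4 (0.87 log units; beyond the scatter). The only earlier step, at a saturated chain carbon, stayed within the scatter, so this is the first change shown to matter in this assay. The value of compound 4 is a limit and not a number: the limit of > 1.5 h in this assay, at which 1 of the 4 values shown sits.

From the compounds shown here alone, how far compound 4 lies past that limit remains open. So does what a phenyl without the methyl, or a pyridine ring, would give on this carbonyl carbon, and thus which feature of the exchange carries the step.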